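Bromobenzyl thioether in place of benzimidazolylmethyl thioether

This account rests on a few compounds, and the source may have more. Where it says the series, first, only, none or still open, it means among the compounds named here.

Measured so far in a functional assay on MGC-803 cells (Homo sapiens) for inhibition, read by MTT assay, with a stated time of 72 h; on this read-out lower numbers stand for stronger inhibition and higher numbers for weaker inhibition:
compound 1, `Cc1ccc(CSc2nc3nc(C)cc(Nc4cc(-c5ccccc5)[nH]n4)n3n2)cc1`, gives 6960 nM;
compound 2, `Cc1cc(Nc2cc(-c3ccccc3)[nH]n2)n2ncnc2n1`, gives 21700 nM;
compound 3, `Cc1cc(Nc2cc(-c3ccccc3)[nH]n2)n2nc(SCc3nc4ccccc4[nH]3)nc2n1`, gives 1790 nM.

Compound 3 gives the lowest number of the three. The two steps that lead to it read a 3.9-fold lower number from compound 1 to compound 3 (0.59 log units; beyond the scatter) and a 12-fold lower number from compound 2 to compound 3 (1.08 log units; beyond the scatter), both beyond the scatter, so compound 3 stands as the strongest of the measured set.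

Compound 4, `Cc1cc(Nc2cc(-c3ccccc3)[nH]n2)n2nc(SCc3ccccc3Br)nc2n1`, is not yet measured. It differs from compound 3 as follows: 2-bromophenyl in place of 1H-benzimidazol-2-yl on a saturated chain carbon bound to a sulfur.

Among the compounds with values here, the step that bears on this change is the one from compound 1 to compound 3, a 3.9-fold lower number from compound 1 to compound 3 (0.59 log units; beyond the scatter), where 1H-benzimidazol-2-yl replaced 4-methylphenyl on a saturated chain carbon bound to a sulfur. Compound 4 carries a plain carbocyclic ring at that position again, as compound 1 does, so the expectation is a move back toward the number of compound 1. The step from compound 2 to compound 1, the reverse of a 3.1-fold higher number from compound 1 to compound 2 (0.49 log units; beyond the scatter), shows that any group on that sulfur already helps over hydrogen, so compound 4 is expected to stay well below compound 2.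

In this assay compound 4 is therefore expected to give about 5000 nM, with a range of 2000 nM to 12000 nM, that is an estimated step of a 2.8-fold higher number from compound 3 to compound 4 (0.45 log units; beyond the scatter).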

Compound 4, half-maximal inhibitory concentration: 3650 nM
Estimate against measurement, compound 4: 1.4-fold (0.14 log units) above, and the stated range covers the measured number.
By their numbers in this assay, from the lowest: compound 3; then compounds 4 and 1 (each within the scatter of the next); then compound 2.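

In this assay, replacing 1H-benzimidazol-2-yl with 2-bromophenyl on the saturated chain carbon bound to a sulfur gives a 2.0-fold higher number from compound 3 to compound 4 (0.31 log units; beyond the scatter), so compound 3 now holds its edge over a second carbocyclic ring and not only over the 4-methylphenyl of compound 1. The change of 4-methylphenyl to 2-bromophenyl gives a 1.9-fold lower number from compound 1 to compound 4 (0.28 log units; within the scatter), which lies within the scatter, so 4-methylbenzyl and 2-bromobenzyl cannot be told apart on this read-out, while (2-bromobenzyl)sulfanyl in place of hydrogen gives a 5.9-fold lower number from compound 2 to compound 4 (0.77 log units; beyond the scatter), a second carbocyclic example of the gain over hydrogen. No measurement available here offers an explanation for these differences.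

The compounds shown do not separate the contribution of the nitrogen atoms of 1H-benzimidazol-2-yl from that of its second ring, a question that a pyridinyl or a naphthyl group at the same place would address. Also open, as far as these compounds go, is how an aminomethyl or carboxylic acid group on the phenyl ring, or a longer chain between the sulfur and the ring, would read in this assay.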